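Ethyl to Propyl on a Shared Core

The source may report more compounds than this note shows. Statements on the series, on what has been measured and on what is new or still open speak of the compounds shown alone.

Compound 1 `CCCn1c(-c2ccccc2)nc2c(NC3CCOC3)ncnc21`: 2810 nM
Compound 2 `CCn1c(-c2ccccc2)nc2c(N)ncnc21`: 5780 nM

Both were tested in an assay on CHO cells for displacement of a labelled ligand from adenosine receptor A3 (Homo sapiens), read by scintillation counting, with a stated time of 3 h; on this read-out lower numbers stand for stronger inhibition and higher numbers for weaker inhibition. Compound 2 gives the highest of the two numbers; the nearest, compound 1, gives a lower one, a gap beyond the scatter. Compound 3 `CCCn1c(-c2ccccc2)nc2c(N)ncnc21` is not yet measured. It differs from compound 2 by methyl in place of hydrogen on a saturated chain carbon, two bonds along the chain from an aromatic nitrogen, the chain going from ethyl to propyl. Among the measured compounds shown here, no measured pair shows this change on its own, so its size cannot be read off; compound 1 carries the longer chain but differs in a second place too. A small step, if any beyond the scatter, is expected: a 1.4-fold lower number from compound 2 to compound 3 (0.16 log units; within the scatter). Compound 3 is estimated at 4000 nM, within 1500 nM to 10000 nM.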

Compound 3, inhibition constant: 9280 nM
Beside the measured number, compound 3's estimate is 2.3-fold (0.37 log units) below it, within the range that was stated.
By their numbers in this assay, from the lowest: compound 1; then compounds 2 and 3 (each within the scatter of the next).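

In this assay the chain going from ethyl to propyl gives a 1.6-fold higher number from compound 2 to compound 3 (0.21 log units; within the scatter) and so, on this evidence, the added methyl on this saturated chain carbon cannot be told apart from assay scatter. The other place now has a readable step: hydrogen in place of oxolan-3-yl on a nitrogen on an aromatic ring gives a 3.3-fold higher number from compound 1 to compound 3 (0.52 log units; beyond the scatter) and this one lies beyond the scatter. No measurement shown gives a reason for either step. On these data alone, whether a longer chain, such as butyl, or an amine at the chain's end would give a clear step remains open.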